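The source may hold more compounds than are shown below. What is called first, only, known or untested is meant among the compounds shown, and "the series" means these compounds.

Compound 1 `CCCN(CC1CC1)c1c(C)nc(-c2c(C)cc(C)cc2OC)c2ccccc12` gives 5 nM in an in vitro assay on IMR-32 cells for displacement of a labelled ligand from corticotropin-releasing factor receptor 1 (Homo sapiens); a higher number here means a weaker inhibitor, a lower number a stronger inhibitor.
Compound 2 `CCCN(CCC)c1c(C)nc(-c2ccc(OC)cc2CC)c2ccccc12` gives 36 nM in this assay.
Compound 3 `COc1cc(C)cc(C)c1-c1nc(C)c(N(CC2CC2)CC2CC2)c2ccccc12` gives 7 nM in this assay.

Compound 2 has the highest number of the three; compound 3 and compound 1 both sit lower, beyond the scatter. Compound 4 `CCCN(CCC)c1c(C)nc(-c2ccc(OC)cc2OC)c2ccccc12` differs from compound 2 by methoxy in place of ethyl on an aromatic carbon. Within the data shown here, no measured step covers a change on this aromatic ring: the only single-point step, a 1.4-fold higher number from compound 1 to compound 3 (0.15 log units; within the scatter), concerns the chain on the ring nitrogen and does not bear on it. Among the measured compounds shown here, compound 1 and compound 3 carry a different substitution on that aryl ring and give lower numbers than compound 2, but they differ from compound 2 in more than one place, so no step can be drawn from them. The expectation for compound 4 is therefore broad, with a modest expected move toward lower numbers, a 1.8-fold lower number from compound 2 to compound 4 (0.26 log units; within the scatter). Compound 4 is estimated at 20 nM in this assay, range 6 nM to 60 nM.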

Compound 4, inhibition constant: 42 nM
For compound 4 the middle estimate is 2.1-fold (0.32 log units) below the measured one; the range from low to high includes it.
By their numbers in this assay, from the lowest: compounds 1 and 3 (each within the scatter of the next); then compounds 2 and 4 (each within the scatter of the next).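

In this assay, methoxy in place of ethyl on this aromatic carbon, ortho to a large group, gives a 1.2-fold higher number from compound 2 to compound 4 (0.07 log units; within the scatter) and so the two groups cannot be told apart at this place. Among these compounds, this is the first readable step on this aryl ring, and the hydrogen-bond acceptor that enters with methoxy brings no difference beyond the scatter in this pair. No supporting data bear on why this pair reads as it does.

Open, going by these compounds, is whether an amine or a longer chain at this place would separate from ethyl and methoxy. On these data alone, it also remains open whether this pair's result holds on the core of any other compound.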